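The source may report more compounds than this note shows. Statements on the series, on what has been measured and on what is new or still open speak of the compounds shown alone.

The shared core appears in compound 1 `CC(C)[C@H]1CC[C@@]2(CO2)[C@H]2C(=O)OCC(C(=O)O)=C[C@H]12`, which in a functional assay on A-375 cells (Homo sapiens) for inhibition, with a stated time of 72 h (a higher number here means a weaker inhibitor, a lower number a stronger inhibitor), gives 1340 nM. Compound 2 `CC(C)[C@H]1CC[C@@](O)(CO)[C@H]2C(=O)OCC(C(=O)O)=C[C@H]12` is a close relative; in this assay compound 2 gives only a limit, > 32000 nM. Compound 3 `CC(C)[C@H]1CC[C@@](O)(CI)[C@H]2C(=O)OCC(C(=O)O)=C[C@H]12` differs from compound 2 by iodo in place of hydroxy on a saturated chain carbon bound to a saturated ring carbon; in this assay compound 3 likewise gives only a limit, > 10000 nM. The step that the two limits leave unreadable from compound 2 to compound 3 therefore has no readable size, because the limit of > 32000 nM in this assay, at which 1 of the 3 values shown sits, and the limit of > 10000 nM in this assay, at which 1 of the 3 values shown sits, are where both of its values sit. Among the compounds with values here, compound 3 thus stands at a limit, and compound 1 holds the only numbered value shown.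

Compound 4 `CC(C)[C@H]1CC[C@@](O)(CCl)[C@H]2C(=O)OCC(C(=O)O)=C[C@H]12` differs from compound 3 by chloro in place of iodo on a saturated chain carbon bound to a saturated ring carbon. The one measured step that bears on this change, from compound 2 to compound 3, is unreadable, so nothing shown points to a step beyond the scatter in this assay in either direction. Compound 4 is therefore expected to give about 15000 nM, between 5000 nM and 50000 nM, most likely again as a limit. The expected step is a step that the limit leaves unreadable from compound 3 to compound 4.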

Compound 4, half-maximal inhibitory concentration: 1310 nM
For compound 4 the middle estimate is 11-fold (1.06 log units) above the measured one; the whole stated range lies above it.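

In this assay, within the data shown here, this position turns out to be sensitive to which group it carries, something the earlier compounds could not show because their values at this place were limits. Putting chloro in place of iodo on a saturated chain carbon bound to a saturated ring carbon gives an at least 7.6-fold lower number from compound 3 to compound 4 (0.88 log units; beyond the scatter), and chloro in place of hydroxy gives an at least 24-fold lower number from compound 2 to compound 4 (1.38 log units; beyond the scatter). Both steps start from a value that is a limit, and they show that a measurable inhibitor can keep the open chain at this carbon, with chloromethyl in place of iodomethyl.

The compounds shown do not tell why chloro stands apart from iodo and hydroxy here. Nor do they show how a fluoro, a bromo or an amine on the same carbon would read in this assay.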